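Methyl on the Four-Membered Ring: Expected Clearance of Compound 3

This account rests on a few compounds, and the source may have more. Where it says the series, first, only, none or still open, it means among the compounds named here.

Compound 1 `C[C@]1(O)C[C@](c2ccnc(C(F)(F)F)c2)([C@H](O)c2ccccn2)C1`: 66.7 mL/min/kg
Compound 2 `O[C@H](c1ccccn1)[C@]1(c2ccnc(C(F)(F)F)c2)C[C@@H](O)C1`: 83.3 mL/min/kg

Of the compounds shown here, two have been measured in an ADME assay on liver for metabolic stability, with Liver microsome (Homo sapiens) as the target, read by LC-MS, using microsomes, with a stated time of 5 h; on this read-out lower numbers stand for slow clearance and higher numbers for fast clearance. Compound 1 gives 66.7 mL/min/kg, and compound 2 gives 83.3 mL/min/kg. The gap between compound 1 and compound 2 falls within the usual scatter of repeated measurements, so the two numbers cannot be told apart, and neither compound can be singled out on this read-out.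

Compound 3 `C[C@]1(O)C[C@@](c2ccnc(C(F)(F)F)c2)([C@H](O)c2ccccn2)C1` has not yet been measured in this assay. It differs from compound 2 in one place: methyl in place of hydrogen on a saturated ring carbon. Going by the values given here, no measured pair shows this change, so there is nothing in the data that fixes its size or direction. Both measured compounds sit close together, and a single-carbon change of this kind is not expected to move the number beyond the scatter. Compound 3 is therefore estimated to give 72 mL/min/kg in this assay, with a range from 42 mL/min/kg to 125 mL/min/kg. The step of a 1.2-fold lower number from compound 2 to compound 3 (0.06 log units; within the scatter) that this estimate means is expected to lie within the scatter.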

Compound 3, clearance: 66.7 mL/min/kg
Compound 3: middle estimate off by 1.1-fold (0.03 log units), on the high side, and the stated range covers the measured number.
By their numbers in this assay, from the lowest: compounds 1, 3 and 2 (each within the scatter of the next).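

In this assay, going by these compounds alone, the first measured pair for this change gives a 1.2-fold lower number from compound 2 to compound 3 (0.10 log units; within the scatter), so methyl in place of hydrogen on a saturated ring carbon of this four-membered ring leaves a step that cannot be told apart from repeat measurements. The second new comparison gives no change at the digits printed from compound 1 to compound 3 (within the scatter), which shows that the configuration as drawn also has no effect on this read-out that can be separated from the scatter, at least for the methyl compounds. This second comparison isolates configuration, with the atoms and bonds held constant, and what allows it to be read that way is: the fact that compounds 1 and 3 differ only in the configuration as drawn.

The compounds shown cover only hydrogen and methyl at this ring carbon, so they leave open whether a longer chain such as an ethyl group, an amine or a carboxylic acid at the same place would give a step beyond the scatter. They also leave open whether the parts of the shared core away from this ring carbon would respond more strongly to change than this position has so far.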